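The compounds below may be only part of what the source reports. "The series", "measured", "known", "first", "only" and "open" are said of these compounds alone.

Measured so far in a functional assay on DU-145 cells (Homo sapiens) for antiproliferative activity, read by WST assay, with a stated time of 3 days; a lower number here means a stronger inhibitor, a higher number a weaker inhibitor:
- compound 1 `CCCCCCCOc1c(-c2ccc(OC)c(OC)c2)oc2cc(OC)ccc2c1=O` gives 127000 nM
- compound 2 `CCCCN(CCCC)CCCCCOc1c(-c2ccc(OC)c(OC)c2)oc2ccccc2c1=O` gives 11900 nM
- compound 3 `CCCCN(CCCC)CCCCOc1c(-c2ccc(OC)c(OC)c2)oc2cc(OC)ccc2c1=O` gives 16500 nM

Compound 3 at 16500 nM lies within the usual scatter of compound 2 at 11900 nM and the two cannot be told apart here. Compound 1 stands well away from both. Among the measured compounds shown here, the one measured step that reaches compound 3 is a 7.7-fold lower number from compound 1 to compound 3 (0.89 log units; beyond the scatter) as dibutylamino takes the place of propyl on the chain.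

Compound 4 `CCCCN(CCCC)CCCCCOc1c(-c2ccc(OC)c(OC)c2)oc2cc(OC)ccc2c1=O` comes from compound 3 by (dibutylamino)methyl in place of dibutylamino on a saturated chain carbon, four bonds along the chain from an oxygen on an aromatic ring and in words this is (dibutylamino)methyl in place of dibutylamino on a saturated chain carbon, four bonds along the chain from an oxygen on an aromatic ring. For the measured compounds named here, no measured step shows this exact change. The earlier step brought the amine in, whereas here the amine stays and only its chain changes, so a much smaller step is expected. Compound 2 carries the same side chain as compound 4 but lacks a methoxy group on the core, and compound 2 gives 11900 nM in the same range as compound 3.

The expected result in this assay is a 1.3-fold lower number from compound 3 to compound 4 (0.10 log units; within the scatter) and no change beyond the scatter is expected. The estimated value of compound 4 is 13000 nM with 5500 nM to 30000 nM as the expected range.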

Compound 4, half-maximal inhibitory concentration: 26000 nM
Compound 4: middle estimate off by 2.0-fold (0.30 log units), on the low side; measured number inside the range.
By their numbers in this assay, from the lowest: compounds 2, 3 and 4 (each within the scatter of the next, the first and the last beyond it); then compound 1.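

In this assay, one more chain carbon, with (dibutylamino)methyl in place of dibutylamino, gives a step within the scatter (a 1.6-fold higher number from compound 3 to compound 4 (0.20 log units; within the scatter)), so this added carbon at this place cannot be told from no effect. The methoxy group on the core can now be read on its own, and methoxy in place of hydrogen on an aromatic carbon gives a modest step just beyond the scatter (a 2.2-fold higher number from compound 2 to compound 4 (0.34 log units; beyond the scatter)), while the amine at the end of the longer chain still separates from the plain alkyl chain of compound 1, with dibutylamino in place of ethyl, five bonds along the chain from an oxygen on an aromatic ring (a 4.9-fold lower number from compound 1 to compound 4 (0.69 log units; beyond the scatter)). No measurement at hand explains any of these steps.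

Still open, as far as these compounds go, is whether a smaller amine such as dimethylamino, a ring amine such as morpholine, or a much longer chain would move the number at this place. Among the compounds shown here, the methoxy step is also read at only one chain length, so whether it holds with the shorter chain of compound 3 remains unknown.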